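The source may hold more compounds than are shown below. What is called first, only, known or untested is meant among the compounds shown, and "the series" means these compounds.

Series notes. Compound 1 `COc1ccccc1N1CCN(CCCCCC(=O)c2cccc(O)c2)CC1` gives 26.8 nM in an assay on isolated protein for binding affinity to 5-hydroxytryptamine receptor 7 (Rattus norvegicus); on this read-out higher numbers stand for weaker inhibition and lower numbers for stronger inhibition. Within the data shown here, compound 2 `COc1ccccc1N1CCN(CCCCCC(=O)c2ccccc2O)CC1` gives 5.8 nM in this assay, the lowest of the two numbers; the only measured step, a 4.6-fold lower number from compound 1 to compound 2 (0.66 log units; beyond the scatter), concerns the hydroxyphenyl end. Compound 3 `CN1CCN(CCCCCC(=O)c2ccccc2O)CC1` differs from compound 2 by methyl in place of 2-methoxyphenyl on an amine nitrogen in a ring. Among the measured compounds shown here, no measured step touches this position, so nothing here sets the size of this assay for this change; the step is taken as likely to raise the number, with wide uncertainty. Compound 3 is expected at 300 nM, range 40 nM to 3000 nM, an estimated step of a 52-fold higher number from compound 2 to compound 3 (1.71 log units; beyond the scatter).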

Compound 3, inhibition constant: > 1000 nM
Compound 3 ended at the assay's limit (the forecaster's own chance of this, stated with the estimate: 10%); middle value at least 3.3-fold (0.52 log units) away from the limit.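

With methyl in place of 2-methoxyphenyl on the amine nitrogen in the ring, this assay shows an at least 170-fold higher number from compound 2 to compound 3 (2.23 log units; beyond the scatter), so the number depends strongly on the group at this position, at least with the 2-hydroxyphenyl end. The value for compound 3 is a limit of the assay and not a number, so the full size of the step stays unknown: the limit of > 1000 nM in this assay, at which 1 of the 3 values shown sits.

The compounds shown leave open whether an unsubstituted phenyl or a benzyl group on this nitrogen would keep the number close to that of compound 2. Also open, going by these compounds, is how the same change behaves with the 3-hydroxyphenyl end of compound 1.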